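This account rests on a few compounds, and the source may have more. Where it says the series, first, only, none or still open, it means among the compounds named here.

Measured so far:
compound 1, `COc1ccc(-c2cnc3nc(N)nc(N4CCN(c5ccc(F)cc5)CC4)c3n2)cc1OC`, 100 nM
compound 2, `CCOc1nc(N)nc2ncc(-c3ccc(OC)cc3)nc12`, > 10000 nM

Compound 1 `COc1ccc(-c2cnc3nc(N)nc(N4CCN(c5ccc(F)cc5)CC4)c3n2)cc1OC` was tested in a functional assay on cells (T-cell, Homo sapiens) for inhibition (on this read-out lower numbers stand for stronger inhibition and higher numbers for weaker inhibition), where compound 1 gives 100 nM. Compound 2 `CCOc1nc(N)nc2ncc(-c3ccc(OC)cc3)nc12` was also tested in this assay, and for compound 2 the result is > 10000 nM, which is a limit of the assay rather than a number; this is the limit of > 10000 nM in this assay, at which 1 of the 2 values shown sits. Going by the values given here, compound 1 therefore stands as the only numerical value in the set, with the other entry being a limit, and no step between measured compounds is available.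

Compound 3 `COc1ccc(-c2cnc3nc(N)nc(N4CCN(C(=O)NCc5ccc(F)cc5)CC4)c3n2)cc1OC` has not yet been measured. It differs from compound 1 as follows: (4-fluorobenzyl)carbamoyl in place of 4-fluorophenyl on an amine nitrogen in a ring. Among the compounds with values here, with no measured step to lean on, compound 3 is expected to sit near compound 1, and the step of a 2.5-fold higher number from compound 1 to compound 3 (0.40 log units; beyond the scatter) is estimated to be small, toward weaker inhibition by no more than a little beyond the usual scatter. Compound 3 is estimated at 250 nM, with a range from 60 nM to 1500 nM.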

Compound 3, half-maximal inhibitory concentration: 37 nM
Compound 3: middle estimate off by 6.8-fold (0.83 log units), on the high side; the measured number lies below the stated range.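

In this assay, putting (4-fluorobenzyl)carbamoyl in place of 4-fluorophenyl on the amine nitrogen in the ring gives a 2.7-fold lower number from compound 1 to compound 3 (0.43 log units; beyond the scatter), a modest move toward stronger inhibition. Going by these compounds alone, the earlier compounds gave no step at all, so this is the first sign that this nitrogen accepts a larger group carrying a carbonyl and an amide hydrogen, and that inhibition is not only kept but improved. Nothing shown here accounts for the gain.

The change alters the link and the atoms that join the fluorophenyl ring to the nitrogen all at once, so the share of the carbonyl and of the longer reach cannot be separated. From the compounds shown here alone, a plain 4-fluorobenzyl group on the same nitrogen, or an unsubstituted benzyl carbamoyl, would bear on that question, and their effect remains open.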